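The compounds below may be only part of what the source reports. "The series", "measured", "known", "first", "only" and "open" are said of these compounds alone.

Going by the values given here, compound 1 `COC(=O)CN1C(=O)c2ccccc2NC1c1ccccc1` is the weakest inhibitor among the three compounds measured so far: in an assay on mitochondria for inhibition of Amine oxidase [flavin-containing] A (Bos taurus), read by fluorescence, with a stated time of 60 min (on this read-out lower numbers stand for stronger inhibition and higher numbers for weaker inhibition), compound 1 gives 930 nM, the highest of the three numbers. Compound 2 `COC(=O)CN1C(=O)c2ccccc2NC1c1ccco1` gives 44 nM in this assay, and compound 3 `COC(=O)CN1C(=O)c2ccccc2NC1c1ccc(OC)cc1` gives 48 nM. Both departures from compound 1 were large: a 21-fold lower number from compound 1 to compound 2 (1.33 log units; beyond the scatter) and a 19-fold lower number from compound 1 to compound 3 (1.29 log units; beyond the scatter), while a 1.1-fold higher number from compound 2 to compound 3 (0.04 log units; within the scatter). Each of these steps alters the group on the saturated ring carbon, not the chain on the amide-type nitrogen.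

Compound 4 `COC(=O)CCN1C(=O)c2ccccc2NC1c1ccccc1` is the untested compound, and it differs from compound 1 in a different place: (methoxycarbonyl)methyl in place of methoxycarbonyl on a saturated chain carbon bound to an amide-type nitrogen in a ring. Among the compounds with values here, none of the measured steps touches this chain, so there is no direct guide to how lengthening it will play out; the two large steps seen so far speak only to the aryl group. Without such a guide, the expectation is that the change from compound 1 to compound 4 produces a 1.0-fold lower number from compound 1 to compound 4 (0.01 log units; within the scatter). Compound 4 is therefore estimated at 900 nM, with a range from 250 nM to 3500 nM.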

Compound 4, half-maximal inhibitory concentration: 92 nM
Estimate against measurement, compound 4: 9.8-fold (0.99 log units) above; measured number below the stated range.
By their numbers in this assay, from the lowest: compounds 2, 3 and 4 (each within the scatter of the next, the first and the last beyond it); then compound 1.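

The chain on the amide-type nitrogen turns out to be a second place where the number can move, since until now only changes to the group on the saturated ring carbon had been seen to shift it. In this assay, the change from (methoxycarbonyl)methyl to 2-(methoxycarbonyl)ethyl gives a 10-fold lower number from compound 1 to compound 4 (1.00 log units; beyond the scatter), even though the counts of hydrogen-bond donors and acceptors stay the same and the ester is kept. Nothing available here explains why lengthening this chain lowers the number.

Still open, on these data alone, is whether a longer chain, such as 3-(methoxycarbonyl)propyl, would lower the number further or raise it again, and whether the ester could give way to a carboxylic acid. Also open, as far as these compounds go, is how the 2-(methoxycarbonyl)ethyl chain behaves when paired with furan-2-yl on the saturated ring carbon.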